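This account rests on a few compounds, and the source may have more. Where it says the series, first, only, none or still open, it means among the compounds named here.

In a functional assay on MDA-MB-436 cells (Homo sapiens) for antiproliferative activity, read by MTT assay, with a stated time of 48 h (on this read-out lower numbers stand for stronger inhibition and higher numbers for weaker inhibition), compound 1 (`C=CS(=O)(=O)N1CCN(c2ncnc3ccc(-c4ccccc4)cc23)CC1`) gives 23400 nM. Compound 2 (`C=CS(=O)(=O)N1CCN(c2ncnc3sc(-c4ccc(C#N)cc4)cc23)CC1`) gives 9170 nM, a lower number than compound 1 shows and within the scatter of compound 3 (`C=CS(=O)(=O)N1CCN(c2ncnc3sc(-c4ccc(N5CCN(C)CC5)cc4)cc23)CC1`), which gives 8760 nM. Compound 4 (`C=CS(=O)(=O)N1CCN(c2ncnc3sc(-c4ccnc(Cl)c4)cc23)CC1`) has not yet been measured. It differs from compound 2 by 2-chloropyridin-4-yl in place of 4-cyanophenyl on an aromatic carbon, with 2-chloropyridin-4-yl in place of 4-cyanophenyl, next to the ring sulfur. For the measured compounds named here, the one measured step at this place, a 1.0-fold lower number from compound 2 to compound 3 (0.02 log units; within the scatter), replaced cyano with 4-methylpiperazin-1-yl. Going by the values given here, no measured compound carries the entering group, so no change beyond the scatter is expected, in either direction, and the estimated step is a 1.0-fold lower number from compound 2 to compound 4 (0.01 log units; within the scatter). For compound 4 the estimated value is 9000 nM, with an expected range of 4500 nM to 18000 nM.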

Compound 4, half-maximal inhibitory concentration: 30100 nM
The estimate for compound 4 lay 3.3-fold (0.52 log units) below the measured number; measured number outside the range, above it.
By their numbers in this assay, from the lowest: compounds 3 and 2 (each within the scatter of the next); then compounds 1 and 4 (each within the scatter of the next).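

In this assay the aromatic carbon next to the ring sulfur proved sensitive to its substituent: a 3.3-fold higher number from compound 2 to compound 4 (0.52 log units; beyond the scatter) lies beyond the scatter, while a 1.0-fold lower number from compound 2 to compound 3 (0.02 log units; within the scatter) stays within it. Replacing 4-cyanophenyl with 2-chloropyridin-4-yl therefore weakened inhibition, although both groups hold one six-membered aromatic ring. No measurement shown accounts for this loss. The compounds shown do not separate the contribution of the ring nitrogen from that of the chlorine. A 4-chlorophenyl or an unsubstituted pyridin-4-yl group at this place would tell them apart.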